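The compounds below may be only part of what the source reports. "The series", "measured", "known", "first", "only" and "open" are said of these compounds alone.

Measured so far:
compound 1 `CC(C)(Oc1ccc(-c2cc(=O)c3ccccc3o2)cc1)C(=O)NC1CCN(Cc2ccccc2)CC1` — > 20000 nM
compound 2 `O=C(COc1ccc(-c2cc(=O)c3ccccc3o2)cc1)NC1CCN(Cc2ccccc2)CC1` — 15500 nM
compound 3 `COc1ccc(CN2CCC(NC(=O)COc3ccc(-c4cc(=O)c5ccccc5o4)cc3)CC2)cc1` — 6800 nM

All three compounds were tested in a functional assay on HepG2 cells (Homo sapiens) for cytotoxicity, read by MTT assay, with a stated time of 72 h; a lower number here means a stronger inhibitor, a higher number a weaker inhibitor. For compound 1 the result is only a limit of the assay, (the limit of > 20000 nM in this assay, at which 1 of the 3 values shown sits), so no number is known for it. Compound 2 gives 15500 nM in this assay, and compound 3 gives 6800 nM. Compounds 2 and 3 differ in one place, (methoxy in place of hydrogen on an aromatic carbon), and that change brought a 2.3-fold lower number from compound 2 to compound 3 (0.36 log units; beyond the scatter).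

Compound 4 `COc1ccc(CN2CCC(NC(=O)C(C)(C)Oc3ccc(-c4cc(=O)c5ccccc5o4)cc3)CC2)cc1` has not yet been measured. It stands to compound 1 as compound 3 stands to compound 2: the change is methoxy in place of hydrogen on an aromatic carbon, the same change in the same kind of place. The difference between the core of compound 1 and the core of compound 2 is not broken down here.

For the measured compounds named here, since only one earlier example of this change exists, the expectation for compound 4 rests on a single step. For compound 4 the step from compound 1 is expected to be an at least 1.1-fold lower number from compound 1 to compound 4 (0.04 log units; that floor lies within the scatter), of a size like that seen from compound 2 to compound 3. Because compound 1 sits at the limit of > 20000 nM in this assay, at which 1 of the 3 values shown sits, the starting point is uncertain, and compound 4 may itself come back as a limit. Compound 4 is estimated at 18000 nM in this assay, likely between 7000 nM and 50000 nM.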

Compound 4, half-maximal inhibitory concentration: 2800 nM
Estimate against measurement, compound 4: 6.4-fold (0.81 log units) above, outside the stated range (below it).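

In this assay, the swap of hydrogen for methoxy, which turns benzyl into 4-methoxybenzyl, gave an at least 7.1-fold lower number from compound 1 to compound 4 (0.85 log units; beyond the scatter), so the number fell on this core as it did on the core of compound 2. The direction of the change therefore carried over from one core to the other, but its size did not stay the same, and a step measured on one core was a poor guide to the size on the other: the same change on two cores in this assay, a 2.3-fold lower number (0.36 log units; beyond the scatter) from compound 2 to compound 3 and an at least 7.1-fold lower number (0.85 log units; beyond the scatter) from compound 1 to compound 4, at least 3.1-fold (0.49 log units) apart, beyond the scatter of two such steps. These two pairs show neither why the size differs nor what a third core would do, and the true step on the core of compound 1 remains unknown, with only its lower bound established, since the starting point is a limit of the assay and not a number: the limit of > 20000 nM in this assay, at which 1 of the 4 values shown sits.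

The compounds shown leave open whether an ethoxy group, a hydroxyl or an amine in place of the methoxy would lower the number in the same way on either core. They also leave open how the methoxy step would behave on a core with a longer chain in its amide linker.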